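The compounds below may be only part of what the source reports. "The series", "measured", "known", "first", "only" and "open" are said of these compounds alone.

Compound 1 `OCc1cn(Cc2ccccc2)c2ccccc12` gives 30 nM in a functional assay on T29Kt1 cells (Homo sapiens) for cytotoxicity, read by sulforhodamine B assay, with a stated time of 3 days (on this read-out higher numbers stand for weaker inhibition and lower numbers for stronger inhibition), where it holds the second highest of three numbers. Its nearest neighbour is compound 2 `OCc1cn(Cc2cccc(F)c2)c2ccccc12` at 20 nM, a change of a 1.5-fold lower number from compound 1 to compound 2 (0.18 log units; within the scatter); its furthest is compound 3 `OCc1cn(Cc2cccc(Cl)c2)c2ccccc12` at 160 nM, a change of a 5.3-fold higher number from compound 1 to compound 3 (0.73 log units; beyond the scatter), and between those two the step is an 8.0-fold higher number from compound 2 to compound 3 (0.90 log units; beyond the scatter). Compound 4 `O=[N+]([O-])c1ccc(Cn2cc(CO)c3ccccc32)cc1` differs from compound 1 by nitro in place of hydrogen on an aromatic carbon. For the measured compounds named here, no measured step involves a nitro group, and the two halogen steps sit on the same ring but differ in size, so the direction is uncertain; a modest weakening seems the likelier outcome because of a 5.3-fold higher number from compound 1 to compound 3 (0.73 log units; beyond the scatter). Compound 4 is expected to give 60 nM, within 15 nM to 250 nM, an estimated step of a 2.0-fold higher number from compound 1 to compound 4 (0.30 log units; within the scatter) in this assay .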

Compound 4, half-maximal inhibitory concentration: 150 nM
Compound 4: the middle estimate sits 2.5-fold (0.40 log units) below what was measured; the measured number falls inside the stated range.
By their numbers in this assay, from the lowest: compounds 2 and 1 (each within the scatter of the next); then compounds 4 and 3 (each within the scatter of the next).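

In this assay, nitro in place of hydrogen on an aromatic carbon, para to a large group, gives a 5.0-fold higher number from compound 1 to compound 4 (0.70 log units; beyond the scatter). This shows that the position does not accept this group of 3 heavy atoms without a modest loss, a step beyond the usual scatter. No measurement here explains that loss. The compounds shown leave open whether the loss follows the nitro group itself or this place on the ring. They also leave open whether an amine or a carboxylic acid here would give a similar number.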